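Closing the Amide Substituent into a Ring

This account rests on a few compounds, and the source may have more. Where it says the series, first, only, none or still open, it means among the compounds named here.

Compound 1, `CCNC(=O)CC1CCc2cc(OC)c(OC)cc21`: 20.4%
Compound 2, `COc1cc2c(cc1OC)C(CC(=O)NC(C)(C)C)CC2`: 31.5%

Both compounds share one core and differ only in the group on the amide nitrogen. For the measured compounds named here, in a functional assay on the whole organism (strain Wistar) for inhibition, with Rattus norvegicus as the target, read by paw edema, with stated times of 60 min and 6 h, at a dose of 100 mg/kg by the oral route (a higher number here means more inhibition at the dose given (going by the name of the read-out), a lower number less inhibition), compound 2 gives the higher of the two numbers, and the only measured step, a number 11.1 percentage points higher from compound 1 to compound 2 (beyond the scatter), places it beyond the scatter above compound 1. Compound 3, `COc1cc2c(cc1OC)C(CC(=O)N1CCCC1)CC2`, is not yet measured and alters the same position: pyrrolidin-1-yl in place of (tert-butyl)amino on a carbonyl carbon. The measured step kept the hydrogen on the nitrogen and only enlarged the alkyl group, whereas this change swaps a group with one hydrogen-bond donor for a ring with none, so the precedent is loose. Going by the values given here, it shows only that a change at this position moved the number, and that tert-butyl in place of ethyl brought a modest rise, but nothing measured covers loss of the donor. The expected step is therefore small, a number 4.5 percentage points lower from compound 2 to compound 3 (within the scatter), within the scatter. Compound 3 is estimated at 27%, with a range from 10% to 44%.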

Compound 3, a percentage reported as inhibition, in the whole organism at one dose (the size of the read-out at that dose, not a potency): 22.2%
Estimate against measurement, compound 3: 4.8 percentage points above, within the range that was stated.
By their numbers in this assay, from the lowest: compounds 1, 3 and 2 (each within the scatter of the next, the first and the last beyond it).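

In this assay, replacing the (tert-butyl)amino group with pyrrolidin-1-yl gives a number 9.3 percentage points lower from compound 2 to compound 3 (within the scatter), while replacing the ethylamino group of compound 1 with the same ring gives a number 1.8 percentage points higher from compound 1 to compound 3 (within the scatter). This is the first change at this carbonyl carbon to remove the amide hydrogen and close the substituent into a ring, and neither step lies beyond the scatter, so the amide hydrogen is not shown to be necessary for the inhibition seen here. Nothing available explains the result in terms of cause.

On these data alone, the ring and the loss of the amide hydrogen arrive together in compound 3, so their separate contributions remain unknown. An open-chain diethylamino group on the same carbonyl carbon could help separate them, and a piperidin-1-yl ring would show whether ring size matters.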